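Thiazole for Chlorophenyl on the Cyclopropane Ring

A few compounds are considered here, and "the series" means these few. Any claim that something is new, unique, unknown or untested is made for them only; others in the source may bear on it.

compound 1, `N[C@@H](CC1CCCCC1)CN(C(=O)[C@@H]1C[C@H]1c1ccccc1)c1ccc(-c2ccccc2)cc1`: 1.7 nM
compound 2, `CC[C@H](C)[C@H](N)CN(C(=O)[C@@H]1C[C@H]1c1ccccc1Cl)c1ccc(-c2ccccc2)cc1`: > 25000 nM

In a functional assay for agonist activity at G protein-coupled receptor 88 (Homo sapiens), read by HTRF and cAMP accumulation (a lower number here means that less compound is needed, a higher number that more compound is needed for the effect), compound 1 gives 1.7 nM. Compound 2 is reported in this assay only as a limit, > 25000 nM, and so stands at the limit of > 25000 nM in this assay, at which 1 of the 2 values shown sits. Compound 3, `CC[C@H](C)[C@H](N)CN(C(=O)[C@@H]1C[C@H]1c1nc(C)cs1)c1ccc(-c2ccccc2)cc1`, differs from compound 2 in one place: 4-methyl-1,3-thiazol-2-yl in place of 2-chlorophenyl on a saturated ring carbon. Going by the values given here, no measured pair carries this change, so its effect can only be guessed; the account expects no strong gain and counts a limit as likely again. Compound 3 is expected to give about 12000 nM in this assay, within 800 nM to 25000 nM. The expected step is an at least 2.0-fold lower number from compound 2 to compound 3 (0.31 log units; beyond the scatter).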

Compound 3, half-maximal effective concentration: 730 nM
Compound 3: the middle estimate sits 16-fold (1.22 log units) above what was measured; measured number outside the range, below it.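

Compound 2 is reported only as a limit in this assay: the limit of > 25000 nM in this assay, at which 1 of the 3 values shown sits. With this side chain, the group on the saturated ring carbon decides whether a value can be read at all: 4-methyl-1,3-thiazol-2-yl in place of 2-chlorophenyl gives an at least 34-fold lower number from compound 2 to compound 3 (1.53 log units; beyond the scatter). From the compounds shown here alone, the true size of this large step remains unknown, since it starts from a limit. Going by these compounds, whether the gain comes from the thiazole ring itself or from its methyl remains open. So does what an unsubstituted 1,3-thiazol-2-yl or a pyridin-2-yl would give at this carbon.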